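The source may report more compounds than this note shows. Statements on the series, on what has been measured and on what is new or still open speak of the compounds shown alone.

Measured so far in a functional assay on MCF7 cells (Homo sapiens) for cytotoxicity, read by sulforhodamine B assay; on this read-out lower numbers stand for stronger inhibition and higher numbers for weaker inhibition:

- compound 1 `O=C(c1ccc(Cl)cc1)c1cc2c(-c3cccnc3)nn(-c3ccccc3)c2[nH]c1=O`: 6.45 ug/mL
- compound 2 `N#Cc1cc2c(-c3cccnc3)nn(-c3ccccc3)c2[nH]c1=S`: 2.7 ug/mL
- compound 3 `CCOC(=O)c1cc2c(-c3cccnc3)nn(-c3ccccc3)c2nc1-c1cccnc1`: 6.9 ug/mL

Compound 1 holds the second highest of the three numbers in this assay. Its nearest neighbour is compound 3, whose value in this assay of 6.9 ug/mL sits within the scatter of compound 1, so the two cannot be told apart on these numbers. Compound 2 is the furthest: in this assay compound 2 gives 2.7 ug/mL, a lower number than compound 1 by a margin beyond the scatter. No pair among these three differs in a single place, so no step can be isolated from the measured set.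

The next compound, compound 4 `Cc1ccc(C(=O)c2cc3c(-c4cccnc4)nn(-c4ccccc4)c3[nH]c2=O)cc1`, keeps the shared core of compound 1 and changes only the pendant aryl ketone: methyl in place of chloro on an aromatic carbon. Nothing in the measured set speaks to this exchange directly. The change is small by count and leaves the donor and acceptor tally untouched, so the expectation for the step from compound 1 to compound 4 in this assay is no shift beyond the scatter: a 1.1-fold higher number from compound 1 to compound 4 (0.04 log units; within the scatter). On that basis compound 4 is estimated at 7 ug/mL in this assay, with a range from 3.5 ug/mL to 14 ug/mL.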

Compound 4, half-maximal inhibitory concentration: 9.9 ug/mL
Beside the measured number, compound 4's estimate is 1.4-fold (0.15 log units) below it, and the stated range covers the measured number.
By their numbers in this assay, from the lowest: compound 2; then compounds 1, 3 and 4 (each within the scatter of the next).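

Methyl in place of chloro, on the aromatic carbon para to a large group, gives a 1.5-fold higher number from compound 1 to compound 4 (0.19 log units; within the scatter) in this assay, and this is the first step in the series that isolates a single place. At this position of the pendant aryl ketone, 4-chlorophenyl and 4-methylphenyl therefore cannot be told apart on these numbers, and the exchange of one substituent for the other leaves the read-out without a shift that stands clear of repeat measurements. No evidence on the properties of either group bears on this result.

Chloro and methyl are only two substituents at this place, so it remains open whether a group of another kind there, such as an amine, a carboxylic acid or a longer chain like butyl, would move the number beyond the scatter, or whether removing the substituent altogether would do so. Among these compounds, also open is what a change elsewhere on the shared core would do, since the only single-place step available so far lies on the pendant aryl ketone.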